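Thiophenyl for ethynyl on the shared core, compound 4

This account rests on a few compounds, and the source may have more. Where it says the series, first, only, none or still open, it means among the compounds named here.

The series shares a ribose-bearing bicyclic core. Compound 1 `COc1nc(N)nc2c1c(-c1cc3ccccc3o1)cn2[C@@H]1O[C@H](CO)[C@@H](O)[C@H]1O` carries a benzofuranyl group and a methoxy group; in a functional assay on HCT-116 cells (Homo sapiens), read by MTT assay, with a stated time of 72 h (on this read-out lower numbers stand for stronger inhibition and higher numbers for weaker inhibition), compound 1 reaches only the limit > 20000 nM, which is a limit of the assay and not a number. Compound 2 `Nc1nc(N)c2c(-c3cc4ccccc4o3)cn([C@@H]3O[C@H](CO)[C@@H](O)[C@H]3O)c2n1`, with amino in place of methoxy on an aromatic carbon, gives 14000 nM; the step of an at least 1.4-fold lower number from compound 1 to compound 2 (0.15 log units; that floor lies within the scatter) cannot be sized beyond its floor because of the limit of > 20000 nM in this assay, at which 1 of the 3 values shown sits. Compound 3 `C#Cc1cn([C@@H]2O[C@H](CO)[C@@H](O)[C@H]2O)c2ncnc(OC)c12`, bearing an ethynyl group and the methoxy group, gives 5140 nM and so stands at the lowest of the two numbers; its gap to compound 2, the nearest, is beyond the scatter.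

Compound 4 `COc1ncnc2c1c(-c1cccs1)cn2[C@@H]1O[C@H](CO)[C@@H](O)[C@H]1O` differs from compound 3 as follows: thiophen-2-yl in place of ethynyl on an aromatic carbon. Within the data shown here, no measured step covers this change, since compound 1 and compound 3 differ in more than one place and show only that the aryl-bearing compounds sit at or beyond the weaker end of the range. Compound 4 is therefore expected to move toward that end, a step of a 2.1-fold higher number from compound 3 to compound 4 (0.33 log units; beyond the scatter), with wide uncertainty. The estimate for compound 4 in this assay is 11000 nM, between 3500 nM and 30000 nM.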

Compound 4, half-maximal inhibitory concentration: 440 nM
The estimate for compound 4 lay 25-fold (1.40 log units) above the measured number, outside the stated range (below it).
By their numbers in this assay, from the lowest: compound 4; then compound 3; then compound 2. At a limit, above all of these: compound 1.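

In this assay, the aromatic carbon two ring bonds from the ring nitrogen proves to be a sensitive site on the shared core, and replacing ethynyl with thiophen-2-yl gives a 12-fold lower number from compound 3 to compound 4 (1.07 log units; beyond the scatter). Among these compounds, the earlier compounds showed no measured step at this position: their only step was amino in place of methoxy, and it can be sized no further than its floor. Among the compounds shown here, this position therefore accepts a five-membered aromatic ring with one sulfur, carrying more heavy atoms than ethynyl, and the read-out improves rather than being lost, though only this one pair supports that reading. Nothing measured here gives a cause for the gain.

As far as these compounds go, it remains open whether the gain is specific to thiophen-2-yl or extends to other groups on the same carbon, such as phenyl, furan-2-yl, thiophen-3-yl or a small amine. Also open is whether amino in place of methoxy on the aromatic carbon would shift the number for compound 4, as no pair shown tests that change with the thiophen-2-yl group in place.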